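A few compounds are considered here, and "the series" means these few. Any claim that something is new, unique, unknown or untested is made for them only; others in the source may bear on it.

Working notes on the series, which so far holds three measured compounds. Compound 1 `COc1ccc(F)cc1N1C(=O)CSC1c1cccc(C(=O)NCCCCc2ccccc2)c1` gives 86% in a functional assay on MG-63 cells (Homo sapiens) for inhibition, read by CCK-8 assay, with a stated time of 72 h, tested at 1 uM; on this read-out lower numbers stand for less inhibition and higher numbers for more inhibition at the one concentration tested (going by the name of the read-out). Compound 2 `Cc1cccc(N2C(=O)CSC2c2cccc(C(=O)NCCCCc3ccccc3)c2)c1` gives 93% in this assay, and compound 3 `O=C(NCCCCc1ccccc1)c1cccc(C2SCC(=O)N2c2cccc(F)c2)c1` gives 92% in this assay. Among these three numbers compound 3 stands second highest; its nearest neighbour is compound 2, with a number 1 percentage points lower from compound 2 to compound 3 (within the scatter), and its furthest is compound 1, with a number 6 percentage points higher from compound 1 to compound 3 (within the scatter). The third measured step, a number 7 percentage points higher from compound 1 to compound 2 (within the scatter), is likewise within the scatter, so the three aryl groups on the ring nitrogen have not yet separated in this read-out.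

Compound 4 `O=C(NCCCCc1ccccc1)c1cccc(C2SCC(=O)N2c2ccccc2F)c1` is not yet measured. It differs from compound 3 as follows: 2-fluorophenyl in place of 3-fluorophenyl on an amide-type nitrogen in a ring. Among the measured compounds shown here, the steps that bear on this change are the exchanges of the aryl group on the same nitrogen, a number 1 percentage points lower from compound 2 to compound 3 (within the scatter) and a number 7 percentage points higher from compound 1 to compound 2 (within the scatter), both within the scatter. On that basis no step beyond the scatter is expected in this assay for compound 4, and the estimated step is a number 2 percentage points lower from compound 3 to compound 4 (within the scatter). Compound 4 is therefore estimated at 90% in this assay, with a range from 80% to 97%.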

Compound 4, a percentage reported as inhibition, at one concentration (the size of the read-out at that concentration, not a potency): 92%
For compound 4 the middle estimate is 2 percentage points below the measured one; the range from low to high includes it.
By their numbers in this assay, from the lowest: compounds 1, 3, 4 and 2 (each within the scatter of the next).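

Exchanging 3-fluorophenyl for 2-fluorophenyl on the amide-type nitrogen in the ring gives no change at the digits printed from compound 3 to compound 4 (within the scatter) in this assay; unlike the earlier exchanges at this nitrogen, this one keeps the same atoms and changes only how they are joined, so it isolates the place of the fluoro group on the phenyl ring, and at this concentration that place does not separate the two compounds. The 2-fluorophenyl group also stays level with the other aryl groups, with a number 1 percentage points lower from compound 2 to compound 4 (within the scatter) and a number 6 percentage points higher from compound 1 to compound 4 (within the scatter), so four aryl groups at this nitrogen now lie within the scatter of one another in this assay. No supporting evidence is available to account for this flat result.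

All four numbers come from a single concentration, so the compounds shown leave open whether these aryl groups would differ in potency across a range of concentrations. They also leave open whether an amine or a carboxylic acid on the phenyl ring at this nitrogen, or a longer chain in place of the one on the amide, would give a step beyond the scatter.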